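A few compounds are considered here, and "the series" means these few. Any claim that something is new, unique, unknown or untested is made for them only; others in the source may bear on it.

Measured compounds:
compound 1 `COc1ccc(CN(C(=O)C2CC2)c2cc(OC)c(OC)c(OC)c2)cc1O` — 80 nM
compound 2 `C/C=C/C(=O)N(Cc1cc(OC)c(OC)c(OC)c1)c1ccc(OC)c(O)c1` — 9160 nM
compound 3 `COc1ccc(CNc2cc(OC)c(OC)c(OC)c2)cc1Cl` — 47800 nM

Going by the values given here, in a functional assay on KYSE-450 cells (Homo sapiens) for inhibition, read by MTT assay, with a stated time of 48 h (on this read-out lower numbers stand for stronger inhibition and higher numbers for weaker inhibition), compound 1 gives the lowest of the three numbers; compound 2 and compound 3 both give higher numbers, each beyond the scatter, but they differ from compound 1 in more than one place, so their values show only that compound 1 is the strongest of the three here. Compound 4 `CCCCC(=O)N(Cc1ccc(OC)c(O)c1)c1cc(OC)c(OC)c(OC)c1` is compound 1 with butyl in place of cyclopropyl on a carbonyl carbon. Among the compounds with values here, no measured pair differs only at that carbonyl substituent, so the numbers give no direct anchor for this step. The expected step from compound 1 to compound 4 in this assay is a modest rise, near the edge of the scatter, a 2.5-fold higher number from compound 1 to compound 4 (0.40 log units; beyond the scatter). For compound 4 the estimate in this assay is 200 nM, expected between 50 nM and 1000 nM.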

Compound 4, half-maximal inhibitory concentration: 300 nM
The estimate for compound 4 lay 1.5-fold (0.18 log units) below the measured number; measured number inside the range.
By their numbers in this assay, from the lowest: compound 1; then compound 4; then compound 2; then compound 3.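

In this assay the carbonyl substituent now has its first direct reading: butyl in place of cyclopropyl gives a 3.8-fold higher number from compound 1 to compound 4 (0.57 log units; beyond the scatter) and no other part of the structure changes. The step is modest and beyond the scatter, so the ring is not required for a nanomolar value at this position, though cyclopropyl gives the lower number of the two. Nothing at hand accounts for the difference.

On these data alone, whether ring loss or chain length drives the step stays open. A propyl chain, a cyclobutyl ring or a chain ending in an amine on the same carbonyl carbon would help separate the two.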